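Bromo in place of chloro: compound 3 to compound 4

The source may hold more compounds than are shown below. What is called first, only, known or untested is meant among the compounds shown, and "the series" means these compounds.

Values so far in a functional assay (a lower number here means a stronger inhibitor, a higher number a weaker inhibitor), for the series:
- compound 1 `CC(C)=CCOc1cc(O)c2c(c1)OC(c1ccccc1)CC2=O` gives 7320 nM
- compound 2 `CC(C)=CCOc1cc(O)c2c(c1)OC(c1ccc(F)cc1)CC2=O` gives 6060 nM
- compound 3 `CC(C)=CCOc1cc(O)c2c(c1)OC(c1cccc(Cl)c1)CC2=O` gives 6060 nM

Compound 3 stands at 6060 nM in this assay and shares that number with compound 2 at the digits shown; all three values sit within the scatter of one another. The next compound is compound 4 `CC(C)=CCOc1cc(O)c2c(c1)OC(c1cccc(Br)c1)CC2=O` which differs from compound 3 by a single change, bromo in place of chloro on an aromatic carbon with bromo in place of chloro on an aromatic carbon, meta to a large group.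

Going by the values given here, no measured step makes this exact exchange, so the evidence is indirect. Swapping hydrogen for chloro gave a 1.2-fold lower number from compound 1 to compound 3 (0.08 log units; within the scatter) and swapping hydrogen for fluoro gave a 1.2-fold lower number from compound 1 to compound 2 (0.08 log units; within the scatter) in the same series. The exchange of 4-fluorophenyl for 3-chlorophenyl gave no change at the digits printed from compound 2 to compound 3 (within the scatter) as well. Each of these steps is small, and none leaves the scatter. Three compounds are a narrow base, and none of them carries bromo. On that basis, no step beyond the scatter is expected in this assay and no direction is favoured. The estimated step is a 1.0-fold lower number from compound 3 to compound 4 (0.02 log units; within the scatter) for now. For compound 4 the estimated value is 5800 nM with an expected range from 3200 nM to 10000 nM as the working bracket.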

Compound 4, half-maximal inhibitory concentration: 4040 nM
The estimate for compound 4 lay 1.4-fold (0.16 log units) above the measured number, and the stated range covers the measured number.
By their numbers in this assay, from the lowest: compounds 4, 2, 3 and 1 (each within the scatter of the next).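

In this assay, bromo in place of chloro on an aromatic carbon, meta to a large group, gives a 1.5-fold lower number from compound 3 to compound 4 (0.18 log units; within the scatter) and so, like the earlier exchanges on this ring, does not leave the scatter. The same holds for the two wider comparisons: bromo in place of hydrogen gives a 1.8-fold lower number from compound 1 to compound 4 (0.26 log units; within the scatter) and 3-bromophenyl in place of 4-fluorophenyl gives a 1.5-fold lower number from compound 2 to compound 4 (0.18 log units; within the scatter). Bromo therefore extends what hydrogen, fluoro and chloro showed, since no pair among compounds 1, 2, 3 and 4 separates beyond the scatter, and these compounds give no basis for ranking the four groups. No measurement is available that would account for these small steps.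

Still open, as far as these compounds go, is whether a group of another kind on this ring, such as an amine, a carboxylic acid or a longer alkoxy chain, would produce a step beyond the scatter. Also open, from the compounds shown here alone, is whether 4-bromophenyl would read like 3-bromophenyl, and whether changes elsewhere on the shared core would matter more than those on this ring.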